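Cyanoguanidine aryl exchange in an aortic relaxation series

A few compounds are considered here, and "the series" means these few. Any claim that something is new, unique, unknown or untested is made for them only; others in the source may bear on it.

Measured compounds:
compound 1, `CC1(C)Oc2ccc(C#N)cc2[C@@H](/N=C(\NC#N)Nc2ccc(Cl)cc2)[C@@H]1O`, 1800 nM
compound 2, `CC1(C)Oc2ccc(C#N)cc2[C@@H](n2c(O)nc3ccccc32)[C@@H]1O`, 41000 nM

Of the compounds shown here, two sharing the same benzopyran core have been measured in a functional assay (aorta) with Rattus norvegicus as the target; a lower number here means a stronger inhibitor, a higher number a weaker inhibitor. Compound 1, `CC1(C)Oc2ccc(C#N)cc2[C@@H](/N=C(\NC#N)Nc2ccc(Cl)cc2)[C@@H]1O`, carries a cyanoguanidine bearing a 4-chlorophenyl group and gives 1800 nM in this assay. Compound 2, `CC1(C)Oc2ccc(C#N)cc2[C@@H](n2c(O)nc3ccccc32)[C@@H]1O`, carries instead a bicyclic hydroxy-substituted nitrogen heterocycle on the core and gives 41000 nM. Of the two numbers, compound 1 has the lower one, and the gap to compound 2 lies beyond the usual scatter of the method.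

Compound 3, `COC(=O)c1cccc(N/C(=N/[C@@H]2c3cc(C#N)ccc3OC(C)(C)[C@H]2O)NC#N)c1`, has not yet been measured. It keeps the cyanoguanidine of compound 1 and differs from it in one place only:

3-(methoxycarbonyl)phenyl in place of 4-chlorophenyl on an amine nitrogen

Going by the values given here, no measured pair in this set isolates such an exchange on the amine nitrogen, so the size of the step cannot be read from the data. Because compound 1 stands at 1800 nM with the 4-chlorophenyl group, a modest weakening toward a higher number is expected for compound 3 on going to the 3-(methoxycarbonyl)phenyl group, with the expected step from compound 1 to compound 3 being a 1.9-fold higher number from compound 1 to compound 3 (0.29 log units; within the scatter). Compound 3 is therefore estimated at 3500 nM in this assay, within a range of 900 nM to 14000 nM.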

Compound 3, half-maximal inhibitory concentration: 4100 nM
Compound 3: the middle estimate sits 1.2-fold (0.07 log units) below what was measured; low and high end bracket the measured number.
By their numbers in this assay, from the lowest: compound 1; then compound 3; then compound 2.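

In this assay, replacing 4-chlorophenyl with 3-(methoxycarbonyl)phenyl on the amine nitrogen of the cyanoguanidine gives a 2.3-fold higher number from compound 1 to compound 3 (0.36 log units; beyond the scatter), the first readable size for a change at this position. The step is modest, although the entering group has 10 heavy atoms and 2 hydrogen-bond acceptors, while the leaving group has 7 heavy atoms and 0 hydrogen-bond acceptors, so this nitrogen accepts a quite different aryl substituent at only a limited cost in this one exchange. No measurement presented here accounts for the step.

The exchange removes the chlorine and introduces the methoxycarbonyl group in a single change, so the compounds shown leave open how much of the step belongs to each. From the compounds shown here alone, how a plain phenyl group, or a 3-carboxyphenyl group with a carboxylic acid in place of the methyl ester, would stand on the same amine nitrogen also remains open.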